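This account rests on a few compounds, and the source may have more. Where it says the series, first, only, none or still open, it means among the compounds named here.

In a functional assay on cells for antagonist activity at P2X purinoceptor 7 (Homo sapiens), read by ELISA (on this read-out higher numbers stand for weaker inhibition and lower numbers for stronger inhibition), compound 1 `Cc1ccc(-n2ncc(=O)[nH]c2=O)cc1C(=O)NCC1(O)CCCCCC1` gives 700 nM. Compound 2 `O=C(NCC1CCOCC1)c1cc(-n2ncc(=O)[nH]c2=O)ccc1Cl` gives only a limit of this assay, > 5000 nM, not a number; its value sits at the limit of > 5000 nM in this assay, at which 1 of the 2 values shown sits. Compound 3 `CCCCCNC(=O)c1cc(-n2ncc(=O)[nH]c2=O)ccc1Cl` has not yet been measured in this assay. It differs from compound 2 by butyl in place of oxan-4-yl on a saturated chain carbon bound to an amide-type nitrogen. Among the compounds with values here, no measured pair shows a step of this kind, so the step that the limit leaves unreadable from compound 2 to compound 3 is expected to be none beyond the scatter. Compound 3 is therefore estimated at 6000 nM, with a range from 1500 nM to 30000 nM.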

Compound 3, half-maximal inhibitory concentration: 2800 nM
Beside the measured number, compound 3's estimate is 2.1-fold (0.33 log units) above it; the range from low to high includes it.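

With butyl in place of oxan-4-yl on a saturated chain carbon bound to an amide-type nitrogen, this assay shows an at least 1.7-fold lower number from compound 2 to compound 3 (0.25 log units; that floor lies within the scatter). An open chain without the ring or its oxygen therefore still gives a readable number on the shared core. The true size of this step stays unknown, as compound 2 has only a limit and not a number: the limit of > 5000 nM in this assay, at which 1 of the 3 values shown sits.

The compounds shown leave open how a longer chain such as hexyl would read at this position. They also leave open what an amine or a carboxylic acid at the end of the chain would do.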